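Working notes: trifluoromethyl additions in a growth-inhibition series

The source may hold more compounds than are shown below. What is called first, only, known or untested is meant among the compounds shown, and "the series" means these compounds.

Measured so far:
compound 1 `O=S(=O)(NCCCNCc1ccc(C(F)(F)F)cc1)c1cc(C(F)(F)F)cc(C(F)(F)F)c1` — 2500 nM
compound 2 `O=S(=O)(NCCCCCCNCc1ccc(Br)cc1)c1cccc(C(F)(F)F)c1` — 5970 nM
compound 3 `O=S(=O)(NCCCNCc1ccccc1)c1cc(C(F)(F)F)cc(C(F)(F)F)c1` — 11000 nM

All three numbers come from a functional assay on MIA PaCa-2 cells (Homo sapiens) for inhibition, read by MTT assay, with a stated time of 72 h; on this read-out lower numbers stand for stronger inhibition of growth and higher numbers for weaker inhibition of growth. Within the data shown here, the one single-point change measured so far is trifluoromethyl in place of hydrogen on an aromatic carbon, and it gives a 4.4-fold lower number from compound 3 to compound 1 (0.64 log units; beyond the scatter). Compound 2 sits nearest compound 3, within the scatter, and furthest from compound 1, beyond it. The difference between the cores of compound 2 and compound 3 is not broken down here.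

Compound 4 `O=S(=O)(NCCCCCCNCc1ccc(Br)cc1)c1cc(C(F)(F)F)cc(C(F)(F)F)c1` is not yet measured. It differs from compound 2 by trifluoromethyl in place of hydrogen on an aromatic carbon. This is the same kind of change as that from compound 3 to compound 1, but not the same: there the new group entered para to a large group on the benzyl ring, whereas here it enters meta to a large group and meta to a trifluoromethyl group on the other ring. Since compound 2 already gives 5970 nM and the earlier step was modest, a smaller step is expected for compound 4 in this assay, namely a 1.9-fold lower number from compound 2 to compound 4 (0.27 log units; within the scatter). For compound 4 the estimated value is 3200 nM, with a range from 1300 nM to 7500 nM.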

Compound 4, concentration for 50% growth inhibition: 2970 nM
For compound 4 the middle estimate is 1.1-fold (0.03 log units) above the measured one; measured number inside the range.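

In this assay, trifluoromethyl in place of hydrogen on an aromatic carbon gives a 2.0-fold lower number from compound 2 to compound 4 (0.30 log units; within the scatter), so on the core of compound 2 this step alone cannot be told apart from repeat measurements. Set beside the earlier step, the new one does not separate from it: the same change on two cores in this assay, a 4.4-fold lower number (0.64 log units; beyond the scatter) from compound 3 to compound 1 and a 2.0-fold lower number (0.30 log units; within the scatter) from compound 2 to compound 4, 2.2-fold (0.34 log units) apart, within the scatter of two such steps. The change can therefore be carried between these two cores with no measurable difference in step size, but two pairs do not show a fixed step size across the series, and a real difference of moderate size between the cores is not excluded.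

Still open, going by these compounds, is whether a nitrile or a methoxy group in place of trifluoromethyl on the same aromatic carbon would give a step of like size. Also open, on these data alone, is whether the step holds on a core with a longer chain than that of compound 4, or with an amide in place of the secondary amine.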